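The source may hold more compounds than are shown below. What is called first, only, known or untested is meant among the compounds shown, and "the series" means these compounds.

Working notes on the series. In a functional assay for inhibition, with Homo sapiens as the target (a higher number here means a weaker inhibitor, a lower number a stronger inhibitor), compound 1 `COc1cc(OC)c(C(=O)/C=C/c2ccc(Cl)cc2)c(OC)c1` gives 970 nM and compound 2 `COc1cc(OC)c(C(=O)/C=C/c2cccc3ccccc23)c(OC)c1` gives 1350 nM, so compound 1 stands level with compound 2 within the scatter. Compound 3 `COc1cc(OC)c(C(=O)/C=C/c2ccccn2)c(OC)c1` remains unmeasured. Its change from compound 1 is pyridin-2-yl in place of 4-chlorophenyl on a double-bonded chain carbon bound to a double-bonded chain carbon, with pyridin-2-yl in place of 4-chlorophenyl on a double-bonded chain carbon bound to a double-bonded chain carbon. For the measured compounds named here, no measured pair isolates this kind of change, so the direction and size are a judgement. A move to a weaker number in this assay is expected, with an estimated step of a 3.1-fold higher number from compound 1 to compound 3 (0.49 log units; beyond the scatter). For compound 3 the estimated value is 3000 nM, with an expected range of 800 nM to 12000 nM.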

Compound 3, half-maximal inhibitory concentration: 596 nM
For compound 3 the middle estimate is 5.0-fold (0.70 log units) above the measured one, outside the stated range (below it).
By their numbers in this assay, from the lowest: compounds 3, 1 and 2 (each within the scatter of the next, the first and the last beyond it).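

In this assay, pyridin-2-yl in place of 4-chlorophenyl on a double-bonded chain carbon bound to a double-bonded chain carbon gives a 1.6-fold lower number from compound 1 to compound 3 (0.21 log units; within the scatter) and so leaves the two compounds level. At this place, then, the series holds its number with a ring bearing a hetero atom and a hydrogen-bond acceptor, and the chlorine of compound 1 is not required. No measurement at hand accounts for this result. Open, on these data alone, is whether pyridin-3-yl or pyridin-4-yl in the same place would read the same in this assay. As far as these compounds go, a non-aromatic group there, such as a piperidine, or a carboxylic acid on the ring also remains open.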